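Moving the aryl group on the sulfonyl from fluorine to methoxy

This account rests on a few compounds, and the source may have more. Where it says the series, first, only, none or still open, it means among the compounds named here.

Three compounds share one core and differ only in the aryl group on the sulfonyl sulfur. Compound 1 `O=C(c1ccc(OCCCN2CC[C@H](NS(=O)(=O)c3cccc(Cl)c3)C2)cc1)C1CC1` gives 700 nM in an assay on isolated protein for binding affinity to histamine H2 receptor (Homo sapiens); a higher number here means a weaker inhibitor, a lower number a stronger inhibitor; compound 2 `O=C(c1ccc(OCCCN2CC[C@H](NS(=O)(=O)c3ccc(Br)cc3)C2)cc1)C1CC1` gives 290 nM; compound 3 `O=C(c1ccc(OCCCN2CC[C@H](NS(=O)(=O)c3ccccc3F)C2)cc1)C1CC1` gives 1550 nM, the highest of the three numbers. The steps show a 2.4-fold lower number from compound 1 to compound 2 (0.38 log units; beyond the scatter), a 2.2-fold higher number from compound 1 to compound 3 (0.35 log units; beyond the scatter) and a 5.3-fold higher number from compound 2 to compound 3 (0.73 log units; beyond the scatter). Compound 4 `COc1ccc(S(=O)(=O)N[C@H]2CCN(CCCOc3ccc(C(=O)C4CC4)cc3)C2)cc1` differs from compound 3 by 4-methoxyphenyl in place of 2-fluorophenyl on a sulfonyl sulfur. The step from compound 2 to compound 3 bears most on this change, since compound 2 also carries a 4-substituted phenyl, so a lower number is expected for compound 4, roughly a 3.9-fold lower number from compound 3 to compound 4 (0.59 log units; beyond the scatter). The estimate for compound 4 is 400 nM, with a range from 150 nM to 1100 nM.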

Compound 4, inhibition constant: 1000 nM
Estimate against measurement, compound 4: 2.5-fold (0.40 log units) below; the range from low to high includes it.
By their numbers in this assay, from the lowest: compound 2; then compounds 1, 4 and 3 (each within the scatter of the next, the first and the last beyond it).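

In this assay, methoxy in place of bromo on an aromatic carbon gives a 3.4-fold higher number from compound 2 to compound 4 (0.54 log units; beyond the scatter), so a 4-substituted phenyl alone does not secure the lower number of compound 2. The other two steps, a 1.6-fold lower number from compound 3 to compound 4 (0.19 log units; within the scatter) and a 1.4-fold higher number from compound 1 to compound 4 (0.15 log units; within the scatter), leave those pairs indistinguishable. No evidence here explains the gap between bromo and methoxy. Going by these compounds, it remains open whether the lower number is particular to bromo, or whether 4-chlorophenyl, 4-methylphenyl or 4-aminophenyl would match it.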